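Trimming the Sulfur Substituent of Compound 3

A few compounds are considered here, and "the series" means these few. Any claim that something is new, unique, unknown or untested is made for them only; others in the source may bear on it.

Three compounds have been measured in an assay on isolated protein for binding affinity to Equilibrative nucleoside transporter 1 (Homo sapiens); on this read-out higher numbers stand for weaker inhibition and lower numbers for stronger inhibition:
- compound 1, `O=[N+]([O-])c1ccc2c(c1)CN(c1ncnc3c1nc1n3[C@@H]3O[C@H](CO1)[C@@H](O)[C@H]3O)CC2`, gives 331 nM
- compound 2, `Cc1ccc(CSc2ncnc3c2ncn3[C@@H]2O[C@H](CO)[C@@H](O)[C@H]2O)cc1`, gives 457 nM
- compound 3, `Nc1nc(SCc2cccc(Br)c2)c2ncn([C@@H]3O[C@H](CO)[C@@H](O)[C@H]3O)c2n1`, gives 2880 nM

Compound 3 stands at the highest number of the three in this assay. Its nearest neighbour is compound 2, whose number is lower by a margin beyond the scatter, and compound 1 lies further still below it. Compound 3 is therefore the weakest inhibitor among these three.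

Compound 4, `Nc1nc(SI)c2ncn([C@@H]3O[C@H](CO)[C@@H](O)[C@H]3O)c2n1`, has not yet been measured. It differs from compound 3 in one place: iodo in place of 3-bromobenzyl on a sulfur. The six-membered carbon ring with its bromine is gone, and a single iodine now sits on the sulfur.

For the measured compounds named here, no measured pair shows this kind of step, so the expectation rests only on the position of compound 3. Given that compound 3 already gives 2880 nM in this assay, compound 4 is expected to move further toward weaker inhibition, with a 3.5-fold higher number from compound 3 to compound 4 (0.54 log units; beyond the scatter) as the estimated step. For compound 4 the estimate in this assay is 10000 nM, within a range from 2500 nM to 40000 nM.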

Compound 4, half-maximal inhibitory concentration: 81300 nM
Compound 4: middle estimate off by 8.1-fold (0.91 log units), on the low side; the whole stated range lies below it.
By their numbers in this assay, from the lowest: compounds 1 and 2 (each within the scatter of the next); then compound 3; then compound 4.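

In this assay, iodo in place of 3-bromobenzyl on a sulfur brings a 28-fold higher number from compound 3 to compound 4 (1.45 log units; beyond the scatter), a large move toward weaker inhibition. For the compounds shown here, this single-place comparison shows that inhibition at this position depends strongly on the substituent, and that a single iodine on the sulfur does not preserve the level seen with the 3-bromobenzyl group, which the earlier compounds could not show because no two of them differed in one place. Nothing at hand bears on why this step is so large. The compounds shown leave open whether the loss follows the six-membered aromatic ring or its bromine, a question that a plain benzyl on this sulfur would address. On these data alone, how an ethyl group, a longer alkyl chain or an amine would compare in this place also remains open.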